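Dimethoxyphenyl in Place of Dichlorophenyl: What Compound 4 May Show

This account rests on a few compounds, and the source may have more. Where it says the series, first, only, none or still open, it means among the compounds named here.

Of the compounds shown here, three have been tested in a functional assay on SK-MEL-5 cells (Homo sapiens) for cytotoxicity, read by sulforhodamine B assay, with a stated time of 48 h, tested at 0.01 uM; a lower number here means a stronger effect, a higher number a weaker effect of the compound at the concentration tested. Compound 1 `COc1ccc(-c2cc(/C=C/C(=O)c3ccc(OC)c(OC)c3)[nH]n2)cc1` gives 90%, compound 2 `COc1cc(-c2cc(/C=C/C(=O)c3ccc(Cl)c(Cl)c3)[nH]n2)cc(OC)c1OC` gives 98%, and compound 3 `COc1ccc(-c2cc(/C=C/C(=O)c3ccc(N)cc3)[nH]n2)cc1` gives 97%. Compound 2 carries the highest of these three numbers, yet compound 3 and compound 1 both sit within the usual scatter of it, so no real separation among them can be claimed; all three leave most of the cells unaffected at this concentration. Compound 4 `COc1ccc(C(=O)/C=C/c2cc(-c3cc(OC)c(OC)c(OC)c3)n[nH]2)cc1OC` has not been measured. It differs from compound 2 in one place: 3,4-dimethoxyphenyl in place of 3,4-dichlorophenyl on a carbonyl carbon. No change between measured compounds is available, and nothing here points to a step beyond the scatter in this assay in either direction. For compound 4 the expected value is 93%, within 80% to 103%. The expected step is a number 5 percentage points lower from compound 2 to compound 4 (within the scatter), staying within the scatter.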

Compound 4, a percentage reported as activity, at one concentration (the size of the read-out at that concentration, not a potency): 97%
Estimate against measurement, compound 4: 4 percentage points below; the measured number falls inside the stated range.
By their numbers in this assay, from the lowest: compounds 1, 3, 4 and 2 (each within the scatter of the next).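

In this assay, within the data shown here, 3,4-dimethoxyphenyl in place of 3,4-dichlorophenyl on a carbonyl carbon gives a number 1 percentage points lower from compound 2 to compound 4 (within the scatter) and provides the first one-place comparison in this set. At this concentration the two groups cannot be told apart, even though the entering group has hydrogen-bond acceptors and the leaving group has none. No measurement at hand offers an explanation for this result.

On these data alone, it remains open whether an amine or a carboxylic acid on this phenyl ring would give a number beyond the scatter. The same question stands for a longer chain in place of the ring.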